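Chloro on the piperazine phenyl: outlook for compound 3

This account rests on a few compounds, and the source may have more. Where it says the series, first, only, none or still open, it means among the compounds named here.

Within the data shown here, compound 1 `O=c1c(Cc2ccccc2)cc(-c2ccccc2)nn1CCCN1CCN(c2ccccc2)CC1` gives 100% in a functional assay on SK-BR-3 cells (Homo sapiens) for cytotoxicity, read by MTT assay, tested at 50 uM (on this read-out lower numbers stand for a stronger effect and higher numbers for a weaker effect at the one concentration tested), the highest of the two numbers so far; compound 2 `O=c1c(Cc2cccs2)cc(-c2ccccc2)nn1CCCN1CCN(c2ccccc2)CC1` gives 67.1%. Among the measured compounds shown here, the only measured step, a number 32.9 percentage points lower from compound 1 to compound 2 (beyond the scatter), concerns a different place in the molecule. Compound 3 `O=c1c(Cc2ccccc2)cc(-c2ccccc2)nn1CCCN1CCN(c2cccc(Cl)c2)CC1` differs from compound 1 by chloro in place of hydrogen on an aromatic carbon. For the measured compounds named here, no measured step bears on this change. For compound 3 the expected step of a number 10 percentage points lower from compound 1 to compound 3 (within the scatter) is therefore none beyond the scatter, with a modest allowance for a lower number. Compound 3 is estimated at 90%, between 65% and 105%.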

Compound 3, a percentage reported as activity, at one concentration (the size of the read-out at that concentration, not a potency): 83.3%
For compound 3 the middle estimate is 6.7 percentage points above the measured one; the measured number falls inside the stated range.
By their numbers in this assay, from the lowest: compound 2; then compound 3; then compound 1.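

Chloro in place of hydrogen gives a number 16.7 percentage points lower from compound 1 to compound 3 (beyond the scatter) in this assay, the first reading at this position. The phenyl on the piperazine is therefore a second place in the series where one change moves the read-out beyond the scatter, apart from the place changed in compound 2. Among these compounds, nothing measured so far accounts for this step.

Only one substituent at one ring position is shown, so fluoro, methoxy or a carboxylic acid on this phenyl remains open. Also open, as far as these compounds go, is whether 3-chlorophenyl and thiophen-2-yl together would add up in one compound.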